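Trimming a fluorine from the trifluoromethyl group

A few compounds are considered here, and "the series" means these few. Any claim that something is new, unique, unknown or untested is made for them only; others in the source may bear on it.

Measured compounds:
compound 1, `O=C([C@@H]1CCCN(S(=O)(=O)c2ccc(S(=O)(=O)N3CC[C@@H](O)C3)cc2)C1)N1CCC(F)(F)CC1`, 135 nM
compound 2, `CCN(CC)S(=O)(=O)c1ccc(S(=O)(=O)N2CCC[C@@H](C(=O)N3CCC(C(F)(F)F)CC3)C2)cc1`, 110 nM
compound 3, `CC(C)S(=O)(=O)c1ccc(S(=O)(=O)N2CCC[C@@H](C(=O)N3CCC(F)(F)CC3)C2)cc1`, 9.1 nM

These three compounds were tested in a functional assay on MIA PaCa-2 cells (Homo sapiens) for inhibition, read by MTT assay, with a stated time of 3 days; a lower number here means a stronger inhibitor, a higher number a weaker inhibitor. Compound 2 sits second highest of the three numbers: its value lies close to that of compound 1, the two being within the scatter, while compound 3 stands well apart, with a value beyond the scatter lower. Among the measured compounds shown here, the one single-point step among them, a 15-fold lower number from compound 1 to compound 3 (1.17 log units; beyond the scatter), concerns the group on the sulfonyl sulfur and is large.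

Compound 4, `CCN(CC)S(=O)(=O)c1ccc(S(=O)(=O)N2CCC[C@@H](C(=O)N3CCC(C(F)F)CC3)C2)cc1`, is the unmeasured partner of compound 2. The change is hydrogen in place of fluoro on a saturated chain carbon bound to two fluorine atoms and a saturated ring carbon. For the measured compounds named here, no measured step touches this part of the molecule; the step from compound 1 to compound 3 leaves the piperidine substituent untouched, and compounds 1 and 2, which differ in the piperidine substituent among other things, show values within the scatter of each other. The expectation is therefore no step beyond the scatter, no change at the digits printed from compound 2 to compound 4 (within the scatter). Compound 4 is estimated at 110 nM, with a range from 40 nM to 300 nM.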

Compound 4, half-maximal inhibitory concentration: 140 nM
For compound 4 the middle estimate is 1.3-fold (0.10 log units) below the measured one, and the stated range covers the measured number.
By their numbers in this assay, from the lowest: compound 3; then compounds 2, 1 and 4 (each within the scatter of the next).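

Reading the 4-(trifluoromethyl)piperidin-1-yl group on its own for the first time, this assay gives a 1.3-fold higher number from compound 2 to compound 4 (0.10 log units; within the scatter), so trifluoromethyl and difluoromethyl cannot be told apart at this position. The earlier compounds shown here touched this part of the molecule only together with other differences, whereas here hydrogen in place of fluoro is the sole difference, and the removal of that one fluorine leaves the two values within the scatter of each other. No measurement of any other property accompanies this pair, so nothing can be said about what lies behind the result.

Going by these compounds, it remains open whether a methyl group, an amine or a carboxylic acid in place of difluoromethyl would read the same way. Also open, on these data alone, is whether the same replacement would read alike in a compound carrying isopropyl on the sulfonyl sulfur, as compound 3 does.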